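Working notes: replacing phenyl with isopropyl in compound 2

The source may hold more compounds than are shown below. What is called first, only, known or untested is meant among the compounds shown, and "the series" means these compounds.

Measured so far in a functional assay on SW620/5-FU cells (Homo sapiens) for cytotoxicity, read by MTT assay, with a stated time of 48 h, in the presence of a further agent that is not named here; on this read-out higher numbers stand for an effect only at larger amounts of compound and lower numbers for an effect already at smaller amounts:
- compound 1 `COc1cc(NC(=O)NNc2cc(-c3ccccc3)c3cnn(C)c3n2)cc(Cl)n1`: 28700 nM
- compound 2 `Cn1ncc2c(-c3ccccc3)cc(NNC(=O)Nc3cc(Cl)nc(Cl)c3)nc21`: 76900 nM

Of these two, compound 2 stands highest at 76900 nM, so its effect appears only at the larger amount. Next to be read is compound 3 `CC(C)c1cc(NNC(=O)Nc2cc(Cl)nc(Cl)c2)nc2c1cnn2C`, which has isopropyl in place of phenyl on an aromatic carbon, opposite the ring nitrogen: isopropyl in place of phenyl on an aromatic carbon.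

Among the compounds with values here, only one measured step is available, a 2.7-fold higher number from compound 1 to compound 2 (0.43 log units; beyond the scatter). It is modest and beyond the scatter, but it is a change of chloro in place of methoxy, elsewhere in the molecule, with phenyl kept. Within the data shown here, no measured pair shows what happens when phenyl leaves, so that step offers only a rough size and no direction. In this assay, therefore, no step beyond the scatter is expected, though a modest one either way stays possible. The estimate is anchored on compound 2 at 76900 nM, with a wide range.

The expected step is a 1.2-fold lower number from compound 2 to compound 3 (0.07 log units; within the scatter). For compound 3 the estimated value is 65000 nM, with an expected range of 22000 nM to 190000 nM.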

Compound 3, half-maximal effective concentration: 50100 nM
Beside the measured number, compound 3's estimate is 1.3-fold (0.11 log units) above it; low and high end bracket the measured number.
By their numbers in this assay, from the lowest: compounds 1, 3 and 2 (each within the scatter of the next, the first and the last beyond it).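

In this assay, the aromatic carbon opposite the ring nitrogen now has its first measured change, and the new step is a 1.5-fold lower number from compound 2 to compound 3 (0.19 log units; within the scatter) and stays inside the usual scatter. The earlier step concerned only chloro in place of methoxy with phenyl kept, whereas this pair shows that, with the rest of compound 2 unchanged, phenyl with its 6 heavy atoms and isopropyl with 3 heavy atoms and no ring read alike on this measure, so an aromatic ring at this place is not needed to hold the number seen for compound 2. No measured information on these compounds accounts for this result.

On these data alone, whether this tolerance extends to other kinds of group at the same carbon remains open, for example an amine, a carboxylic acid or a longer chain. Also open, as far as these compounds go, is whether isopropyl in place of phenyl reads the same with the methoxy of compound 1 kept, and whether any change at this place can bring the number clearly below that of compound 2.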